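Swapping a hexyl chain for a cyclopentyl ring

This account rests on a few compounds, and the source may have more. Where it says the series, first, only, none or still open, it means among the compounds named here.

Among the measured compounds shown here, compound 1 (`CCCCCCC(=O)Nc1ccn([C@@H]2CO[C@H](CO)O2)c(=O)n1`) gives 1040 nM in a functional assay on A549 cells (Homo sapiens) for cytotoxicity, read by sulforhodamine B assay, with a stated time of 72 h (on this read-out lower numbers stand for stronger inhibition and higher numbers for weaker inhibition), and holds the highest of the three numbers measured so far. Compound 2 (`CCCCCCCCCC(=O)Nc1ccn([C@@H]2CO[C@H](CO)O2)c(=O)n1`) at 24 nM and compound 3 (`CCCCCCCCCCCCCCCC(=O)Nc1ccn([C@@H]2CO[C@H](CO)O2)c(=O)n1`) at 4 nM sit lower in this assay as the chain grows longer. Compound 4 (`O=C(Nc1ccn([C@@H]2CO[C@H](CO)O2)c(=O)n1)C1CCCC1`) makes a different change: cyclopentyl in place of hexyl on a carbonyl carbon with cyclopentyl in place of hexyl on a carbonyl carbon. The closest guides are chain lengthenings: a 43-fold lower number from compound 1 to compound 2 (1.64 log units; beyond the scatter) and a 260-fold lower number from compound 1 to compound 3 (2.41 log units; beyond the scatter) were large, and a 6.0-fold lower number from compound 2 to compound 3 (0.78 log units; beyond the scatter) was modest. For the measured compounds named here, none of the measured compounds carries a ring in this place, so the guidance is indirect. An estimated 2.4-fold higher number from compound 1 to compound 4 (0.38 log units; beyond the scatter) is expected in this assay toward weaker inhibition. Compound 4 is estimated at 2500 nM (expected range 700 nM to 9000 nM).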

Compound 4, half-maximal inhibitory concentration: 2970 nM
Estimate against measurement, compound 4: 1.2-fold (0.07 log units) below; measured number inside the range.
By their numbers in this assay, from the lowest: compound 3; then compound 2; then compound 1; then compound 4.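

In this assay, the ring moves the number in the opposite direction to the chain lengthenings, a 2.9-fold higher number from compound 1 to compound 4 (0.46 log units; beyond the scatter), toward weaker inhibition. Among the compounds shown here, this is the first sign that a group on this carbonyl carbon can cost activity, but the change both adds a ring and removes one carbon, so the two effects cannot be separated. No evidence is available to explain the shift. As far as these compounds go, a pentyl chain, with the carbons of cyclopentyl but no ring, could separate them; whether a larger ring, such as cyclohexyl, behaves similarly remains open.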